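The compounds below may be only part of what the source reports. "The series", "measured", "known", "first", "only" and "open" are said of these compounds alone.

Measured so far:
compound 1 `COc1cc(=O)oc2cc(OCc3cccc(Br)c3)ccc12`: 5.75 nM
compound 2 `CC(=O)COc1cc(=O)oc2cc(OCc3cccc(Cl)c3)ccc12`: 26.9 nM

Both compounds were tested in an assay on isolated protein (strain Sprague-Dawley) for inhibition of Amine oxidase [flavin-containing] B (Rattus norvegicus), read by spectrophotometry, with a stated time of 5 min; a higher number here means a weaker inhibitor, a lower number a stronger inhibitor. Of the two numbers, compound 2 gives the higher one, and compound 1 gives the lower one; the gap between them lies beyond the usual scatter of repeated measurements, so compound 1 is the stronger inhibitor of the two.

Compound 3 `CC(=O)c1cc(=O)oc2cc(OCc3cccc(Cl)c3)ccc12` has not yet been measured in this assay. It differs from compound 2 in a single place: acetyl in place of 2-oxopropoxy on an aromatic carbon. Within the data shown here, no measured pair of compounds differs by this same change, so its effect cannot be read from the data, and the expectation rests on the closeness of compound 3 to compound 2. The step of a 1.8-fold lower number from compound 2 to compound 3 (0.25 log units; within the scatter) is expected to be small, toward a slightly lower number, and it may well stay within the scatter. Compound 3 is therefore expected to give about 15 nM, with a likely range from 4 nM to 60 nM.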

Compound 3, half-maximal inhibitory concentration: 39.8 nM
For compound 3 the middle estimate is 2.7-fold (0.42 log units) below the measured one; the measured number falls inside the stated range.
By their numbers in this assay, from the lowest: compound 1; then compounds 2 and 3 (each within the scatter of the next).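

In this assay, putting acetyl in place of 2-oxopropoxy on this aromatic carbon, opposite the ring oxygen, gives a 1.5-fold higher number from compound 2 to compound 3 (0.17 log units; within the scatter) and so leaves the two compounds indistinguishable. For this pair, the position therefore accepts the smaller acetyl group, which has fewer heavy atoms and hydrogen-bond acceptors, about as well as the 2-oxopropoxy chain. No measurement available here explains why the two groups read alike.

On these data alone, whether this position is insensitive to its substituent in general remains open, as an amine, a carboxylic acid or a longer chain might read quite differently. The methoxy group of compound 1 cannot settle this, as that compound also carries bromine on its benzyl group where compound 2 and compound 3 carry chlorine.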